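Halogen versus methyl on the thiophene of a ketone series

The source may hold more compounds than are shown below. What is called first, only, known or untested is meant among the compounds shown, and "the series" means these compounds.

Compound 1 `CC(C)Nc1sc(C(=O)c2ccncc2)c(N)c1C#N`: in an assay for inhibition of Maternal embryonic leucine zipper kinase (Homo sapiens), read by ADP-Glo, with a stated time of 0.5 h (a higher number here means a weaker inhibitor, a lower number a stronger inhibitor), compound 1 gives > 5000 nM, which is a limit of the assay rather than a number.
Compound 2 `CC(C)Nc1sc(C(=O)c2ccc(Br)s2)c(N)c1C#N`: compound 2 gives 122 nM.
Compound 3 `Cc1ccc(C(=O)c2sc(NC(C)C)c(C#N)c2N)s1`: compound 3 gives 494 nM.
Compound 4 `CC(C)Nc1sc(C(=O)c2cc(Cl)cs2)c(N)c1C#N`: not yet measured.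

Among the two real numbers, compound 3 has the higher one, so it is the weaker of the two measured thiophene ketones; its nearest neighbour is compound 2, and the gap shows as a 4.0-fold higher number from compound 2 to compound 3 (0.61 log units; beyond the scatter). Both thiophene ketones stand far from compound 1, where the shared core carries a pyridin-4-yl instead: an at least 40-fold lower number from compound 1 to compound 2 (1.61 log units; beyond the scatter) and an at least 10-fold lower number from compound 1 to compound 3 (1.00 log units; beyond the scatter).

Compound 4 makes one change to compound 3: 4-chlorothiophen-2-yl in place of 5-methylthiophen-2-yl on a carbonyl carbon. Among the measured compounds shown here, the only measured step that speaks to a swap on the thiophene ring is the one from the bromo of compound 2 to the methyl of compound 3, which is modest; here a chloro takes the place of the methyl, though it sits on a different ring carbon. On that basis a modest move toward a lower number is expected, a 2.0-fold lower number from compound 3 to compound 4 (0.30 log units; within the scatter). Compound 4 is therefore estimated at 250 nM, with a range from 80 nM to 800 nM.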

Compound 4, half-maximal inhibitory concentration: 575 nM
For compound 4 the middle estimate is 2.3-fold (0.36 log units) below the measured one, and the stated range covers the measured number.
By their numbers in this assay, from the lowest: compound 2; then compounds 3 and 4 (each within the scatter of the next). At a limit, above all of these: compound 1.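

Swapping 5-methylthiophen-2-yl for 4-chlorothiophen-2-yl on the carbonyl carbon gives a 1.2-fold higher number from compound 3 to compound 4 (0.07 log units; within the scatter) in this assay, so these two thiophene groups cannot be told apart in this measurement. Carrying a halogen on the thiophene is therefore not enough to match compound 2, as compound 4 goes against any such rule and shows a 4.7-fold higher number from compound 2 to compound 4 (0.67 log units; beyond the scatter) and so stays with the methyl compound rather than the bromo one. Compound 4 still keeps well clear of the pyridin-4-yl ketone, with an at least 8.6-fold lower number from compound 1 to compound 4 (0.93 log units; beyond the scatter) as its step, though this step rests on a limit for compound 1 and not on a real number: the limit of > 5000 nM in this assay, at which 1 of the 4 values shown sits.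

From the compounds shown here alone, compounds 2 and 4 differ both in the halogen and in the ring carbon that carries it, so it remains open which of the two sets compound 2 apart, and a 5-chlorothiophen-2-yl or a 4-bromothiophen-2-yl ketone would separate them. Also open is how an amine or a carboxylic acid on the thiophene would read, since every group shown there is a halogen or a methyl.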